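Chalcone cytotoxicity on Huh-7 cells: chloro to hydrogen

The source may hold more compounds than are shown below. What is called first, only, known or untested is meant among the compounds shown, and "the series" means these compounds.

Measured compounds:
compound 1, `COc1cc(O)c(C(=O)/C=C/c2ccc(F)cc2)c(OC)c1`, > 20000 nM
compound 2, `COc1cc(OC)c(C(=O)/C=C/c2ccc(Cl)cc2)c(OC)c1`, 12700 nM
compound 3, `COc1cccc(/C=C/C(=O)c2c(O)cc(OC)cc2OC)c1`, 15000 nM

The read-out throughout is a functional assay on Huh-7 cells (Homo sapiens) for cytotoxicity, with a stated time of 48 h; a lower number here means a stronger inhibitor, a higher number a weaker inhibitor. Compound 2 gives the lowest of the two numbers available in this assay, with 12700 nM. Compound 3 stands nearest to it at 15000 nM; the gap between the two lies within the usual scatter of repeated measurements, so no order between compound 2 and compound 3 can be claimed. Compound 1 returns only a limit, not a number, in this assay: > 20000 nM. One of the three values therefore sits at the limit described in the limit of > 20000 nM in this assay, at which 1 of the 3 values shown sits.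

The unmeasured compound 4, `COc1cc(OC)c(C(=O)/C=C/c2ccccc2)c(OC)c1`, differs from compound 2 in one place: hydrogen in place of chloro on an aromatic carbon. Among the compounds with values here, no step between measured compounds isolates this change, so nothing measured here tells how large it should be. The most that can be said is that the two measured numbers, and the one limit, all sit at weak potency, and compound 4 is expected to remain in the same region, leaning toward a somewhat weaker value than compound 2, though the expected step of a 1.4-fold higher number from compound 2 to compound 4 (0.15 log units; within the scatter) may well fall inside the scatter. For compound 4 a value of 18000 nM is estimated, with a range from 9000 nM to 40000 nM.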

Compound 4, half-maximal inhibitory concentration: 15500 nM
The estimate for compound 4 lay 1.2-fold (0.06 log units) above the measured number, within the range that was stated.
By their numbers in this assay, from the lowest: compounds 2, 3 and 4 (each within the scatter of the next). At a limit, above all of these: compound 1.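

In this assay, within the data shown here, hydrogen in place of chloro on an aromatic carbon, para to a large group, gives a 1.2-fold higher number from compound 2 to compound 4 (0.09 log units; within the scatter), and this is the only step that isolates a change in one place. With chloro or with hydrogen at this position, the two numbers cannot be told apart, so the 4-chlorophenyl group is not required for a value at this level in this assay, and the plain phenyl group serves equally well on the shared core. The data shown give no cause for this result, and nothing measured here bears on why the two compounds cannot be separated.

Going by these compounds, whether a different group at this position, such as an amine, a carboxylic acid or a longer chain of carbon atoms, would give a step beyond the scatter remains open, since chloro and hydrogen alone say little about the reach of this position. Among these compounds, also open is how the other parts of the core contribute, since compound 1 and compound 3 each differ from compound 2 in more than one place and give no step that can be read against it.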